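Swapping the Allene Arm for an Ester Arm

The compounds below may be only part of what the source reports. "The series", "measured", "known", "first", "only" and "open" are said of these compounds alone.

Compound 1 `CCCc1nc(C)c2c(C)nn(C)c(=O)n12` gives > 48000 nM in a functional assay for inhibition, with Homo sapiens as the target; on this read-out higher numbers stand for weaker inhibition and lower numbers for stronger inhibition; this is a limit of the assay, not a number.
Compound 2 `C=C=Cn1nc(C)c2c(C)nc(CCC)n2c1=O` gives > 48000 nM in this assay; this too is a limit, not a number.

Within the data shown here, compound 2 therefore stands only at a limit, and the one further value shown is a limit as well, as the limit of > 48000 nM in this assay, at which 2 of the 2 values shown sit, records. Among the measured compounds shown here, the single step between measured compounds, a step that the two limits leave unreadable from compound 1 to compound 2, cannot be read, since both of its ends are limits.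

Compound 3 `CCCc1nc(C)c2c(C)nn(CC(=O)OCC)c(=O)n12` differs from compound 2 in one place: (ethoxycarbonyl)methyl in place of propa-1,2-dien-1-yl on an aromatic nitrogen. For the measured compounds named here, no measured step bears on this change beyond the unreadable one, so there is nothing to set a size or a direction for this assay.

Given that both measured compounds sit at the limit, compound 3 is expected to sit at or near it too, with a step estimated as a number no higher from compound 2 to compound 3 (the limit leaves the size open). Compound 3 is thus estimated at 48000 nM, with a range from 10000 nM to 200000 nM, and most likely only a limit will be reported again.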

Compound 3, half-maximal inhibitory concentration: > 48000 nM
Compound 3: a limit, no number; the forecaster's own chance of this, stated with the estimate: 80%; the middle value lies on the limit itself.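

In this assay compound 3 gives > 48000 nM, which is a limit and not a number. The steps joining compound 1, compound 2 and compound 3 therefore cannot be read. All the values shown share one reading: the limit of > 48000 nM in this assay, at which 3 of the 3 values shown sit. The compounds shown leave open how strongly any of them inhibits, and whether changing the group on the aromatic nitrogen alters inhibition at all.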